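The source may report more compounds than this note shows. Statements on the series, on what has been measured and on what is new or still open speak of the compounds shown alone.

Of the compounds shown here, three sharing one core have been tested in a functional assay on A-431 cells (Homo sapiens) for cytotoxicity; a lower number here means that less compound is needed, a higher number that more compound is needed for the effect: compound 1 (`COC1=C(C)C(=O)/C(=C(O)/C=C/c2ccc(Br)cc2)C(=O)C1(C)C`) gives 9 ug/mL, compound 2 (`COC1=C(C)C(=O)/C(=C(O)/C=C/c2cccc(OC)c2)C(=O)C1(C)C`) gives 4.5 ug/mL and compound 3 (`COC1=C(C)C(=O)/C(=C(O)/C=C/c2ccc(O)cc2)C(=O)C1(C)C`) gives 14.9 ug/mL. Compound 3 therefore cannot be separated from one of its neighbours, but it is separated from the other. Compound 4 (`COC1=C(C)C(=O)/C(=C(O)/C=C/c2ccc(C)cc2)C(=O)C1(C)C`) alters it in one place: methyl in place of hydroxy on an aromatic carbon. Within the data shown here, two measured steps bear on this swap, since both bring in the same hydroxy group. One is a 1.7-fold higher number from compound 1 to compound 3 (0.22 log units; within the scatter), and the other, a modest one, is a 3.3-fold higher number from compound 2 to compound 3 (0.52 log units; beyond the scatter). Removing the hydroxy group is therefore expected to give a small move towards a lower number, estimated as a 1.8-fold lower number from compound 3 to compound 4 (0.24 log units; within the scatter). The expected value for compound 4 is 8.5 ug/mL, with an estimated range from 4 ug/mL to 17 ug/mL.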

Compound 4, concentration for half-maximal effect: 5.1 ug/mL
Estimate against measurement, compound 4: 1.7-fold (0.22 log units) above, and the stated range covers the measured number.
By their numbers in this assay, from the lowest: compounds 2, 4, 1 and 3 (each within the scatter of the next, the first and the last beyond it).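

In this assay, replacing hydroxy with methyl on this aromatic carbon gives a 2.9-fold lower number from compound 3 to compound 4 (0.47 log units; beyond the scatter), a modest step beyond the scatter. Bromo in the same place cannot be told apart from methyl, with a 1.8-fold lower number from compound 1 to compound 4 (0.25 log units; within the scatter), even though bromo could not be told apart from hydroxy either. The change of ring pattern in a 1.1-fold higher number from compound 2 to compound 4 (0.05 log units; within the scatter) also stays within the scatter, so compound 4 joins compound 2 at the low end of the series. On these data alone, how an amine or a carboxylic acid would behave in this position remains open. Nothing available here explains why hydroxy and methyl differ.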